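Tert-butoxy to phenyl in a cytotoxicity test

The source may report more compounds than this note shows. Statements on the series, on what has been measured and on what is new or still open speak of the compounds shown alone.

Measured in an ADME assay on HEK293 cells (Homo sapiens) for cytotoxicity, with a stated time of 72 h; on this read-out higher numbers stand for an effect only at larger amounts of compound and lower numbers for an effect already at smaller amounts:
Compound 1 `C=C[C@@](C)(/C=C/c1ccc(O)c(/C=C/C(=O)c2ccccc2)c1)CCC=C(C)C` gives > 7410 nM
Compound 2 `CCOC(=O)/C=C/c1cc(/C=C/[C@](C)(/C=C/c2ccc(OC)cc2)CCC=C(C)C)ccc1O` gives > 36600 nM
Compound 3 `COc1ccc(/C=C/[C@@](C)(/C=C/c2ccc(O)c(/C=C/C(=O)OC(C)(C)C)c2)CCC=C(C)C)cc1` gives > 36600 nM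

Compound 3 has no exact number, only the limit > 36600 nM. That is the limit of > 36600 nM in this assay, at which 2 of the 3 values shown sit. The remaining result is the limit of > 7410 nM in this assay, at which 1 of the 3 values shown sits.

Compound 4 `COc1ccc(/C=C/[C@@](C)(/C=C/c2ccc(O)c(/C=C/C(=O)c3ccccc3)c2)CCC=C(C)C)cc1` brings one structural change, (phenyl in place of tert-butoxy on a carbonyl carbon). In words, this is phenyl in place of tert-butoxy on a carbonyl carbon, which turns tert-butoxycarbonyl into benzoyl.

For the measured compounds named here, the one measured step, a step that the two limits leave unreadable from compound 2 to compound 3, has no readable size, so it offers no size to carry over. Compound 1 also carries the benzoyl group, and its result is the limit > 7410 nM. On that basis, a modest shift toward smaller numbers is expected, though this is far from certain. The expected change is an at least 2.4-fold lower number from compound 3 to compound 4 (0.38 log units; beyond the scatter). Another limit instead of a number would be no surprise. For compound 4 the estimate is 15000 nM, with an expected range from 5000 nM to 40000 nM.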

Compound 4, half-maximal effective concentration: > 36600 nM
Compound 4 gave a limit, no number; the forecaster's own chance of this, stated with the estimate: 65%; middle value at least 2.4-fold (0.38 log units) from the limit.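

Compound 4 gives only a limit and no number, as do compound 1, compound 2 and compound 3, so no step linking compound 4 to them can be read: the limit of > 36600 nM in this assay, at which 3 of the 4 values shown sit.

From the compounds shown here alone, what stays open is whether phenyl in place of tert-butoxy changes cytotoxicity at all, and by how much.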